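Ethoxymethyl to methoxycarbonyl on the shared core

The source may hold more compounds than are shown below. What is called first, only, known or untested is meant among the compounds shown, and "the series" means these compounds.

Measured in a functional assay on DU-145 cells (Homo sapiens) for cytotoxicity, read by sulforhodamine B assay, with a stated time of 3 days; a lower number here means that less compound is needed, a higher number that more compound is needed for the effect:
- compound 1 `CCOCc1c(C)coc1-c1ccc2c(c1OC)CCCC2(C)C`: 17.7 uM
- compound 2 `Cc1coc(-c2ccc3c(c2O)CCCC3)c1C(=O)O`: 40.4 uM

Among the measured compounds shown here, only two numbers are available so far. In this assay compound 1 holds the lower of them at 17.7 uM, and so needs less compound for the effect. Compound 2 stands higher at 40.4 uM, a gap beyond the usual scatter. These two compounds differ in more than one place, so their gap cannot be tied to any single group.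

The next compound to be read is compound 3 `COC(=O)c1c(C)coc1-c1ccc2c(c1OC)CCCC2(C)C`, which keeps the core of compound 1 and carries methoxycarbonyl in place of ethoxymethyl on an aromatic carbon. For the measured compounds named here, no measured pair covers this change, so the expectation rests on compound 1 alone and is weakly supported. The expected size is none beyond the scatter, with no firm direction: the estimated change is a 1.1-fold higher number from compound 1 to compound 3 (0.05 log units; within the scatter). In this assay compound 3 is estimated at 20 uM, with an expected range of 8 uM to 50 uM.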

Compound 3, concentration for half-maximal effect: 33.5 uM
Estimate against measurement, compound 3: 1.7-fold (0.22 log units) below; low and high end bracket the measured number.
By their numbers in this assay, from the lowest: compounds 1, 3 and 2 (each within the scatter of the next, the first and the last beyond it).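

In this assay, among the compounds shown here, methoxycarbonyl in place of ethoxymethyl on this aromatic carbon of the five-membered ring gives a 1.9-fold higher number from compound 1 to compound 3 (0.28 log units; within the scatter) and is the first change on the shared core that can be read at a single place. This position therefore accepts either group without a separation beyond the scatter, even though the entering methoxycarbonyl brings a double bond outside the aromatic rings and the leaving ethoxymethyl does not; the statement holds for this one pair only. No measured property of either group is available to explain this reading.

As far as these compounds go, compound 2 differs from both compound 1 and compound 3 in more than one place, so its number adds nothing about this position, and whether the position stays this permissive remains open. From the compounds shown here alone, an amine, a primary amide or a longer alkyl chain on the same carbon would test that, and it is also open whether the same exchange would read alike on a core other than that of compound 1.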